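The source may report more compounds than this note shows. Statements on the series, on what has been measured and on what is new or still open speak of the compounds shown alone.

Series around the shared core of compound 1 `COc1ccc(-c2cnc(NC(=O)c3ccco3)n2C)cc1`, with the group on the carbonyl carbon of the amide varied. In a toxicity assay on THP-1 cells (Homo sapiens) for inhibition (a lower number here means that less compound is tolerated, a higher number that more compound is tolerated), compound 1 gives > 100000 nM, which is a limit of the assay and not a number. Compound 2 `CCC(=O)Nc1ncc(-c2ccc(OC)cc2)n1C` carries ethyl in place of furan-2-yl on the carbonyl carbon. In this assay compound 2 gives > 100000 nM, again a limit of the assay. The step that the two limits leave unreadable from compound 1 to compound 2 therefore has no readable size, since both values sit at the limit of > 100000 nM in this assay, at which 2 of the 2 values shown sit. Compound 2 thus stands at the limit of the assay, with no number of its own.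

Compound 3 `COc1ccc(-c2cnc(NC(=O)c3ccncc3)n2C)cc1` is the next change: pyridin-4-yl in place of ethyl on a carbonyl carbon. Going by the values given here, the only measured step at the carbonyl carbon, a step that the two limits leave unreadable from compound 1 to compound 2, bears on it, and it is unreadable. What the two measured compounds show is only that both sit at the limit of > 100000 nM in this assay, at which 2 of the 2 values shown sit. No step beyond the scatter in this assay is therefore expected, in either direction. The expected step is a number no higher from compound 2 to compound 3 (the limit leaves the size open). Compound 3 is estimated at 100000 nM, with a range from 30000 nM to 300000 nM, and another limit rather than a number is the likeliest report.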

Compound 3, half-maximal cytotoxic concentration: > 100000 nM
Compound 3: no number, only a limit (the forecaster's own chance of this, stated with the estimate: 80%); the middle value lies on the limit itself.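

In this assay compound 3 gives > 100000 nM, again a limit of the assay and not a number. Going by these compounds alone, no step among compound 1, compound 2 and compound 3 can be read, and the values show only this: the limit of > 100000 nM in this assay, at which 3 of the 3 values shown sit. On these data alone, whether furan-2-yl, ethyl and pyridin-4-yl on the carbonyl carbon differ at all in tolerated concentration stays open.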